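The source may hold more compounds than are shown below. What is called first, only, known or untested is meant among the compounds shown, and "the series" means these compounds.

In a functional assay on CFPAC-1 cells (Homo sapiens) for antiproliferative activity, read by MTT assay, with a stated time of 72 h (a lower number here means a stronger inhibitor, a higher number a weaker inhibitor), three compounds have so far been measured:

Compound 1 `O=C1O[C@H]([C@@H](O)Cn2cc(-c3ccc(Br)cc3)nn2)C(OCc2ccccc2)=C1OCc1ccccc1`: 5830 nM
Compound 2 `O=C1O[C@H]([C@@H](O)Cn2cc(CNS(=O)(=O)c3ccc(F)cc3)nn2)C(OCc2ccccc2)=C1OCc1ccccc1`: 34700 nM
Compound 3 `CC(C)(C)c1cn(C[C@H](O)[C@H]2OC(=O)C(OCc3ccccc3)=C2OCc2ccccc2)nn1`: 54900 nM

Compound 1 gives the lowest number of the three, and both other compounds are clearly weaker: the steps were a 6.0-fold higher number from compound 1 to compound 2 (0.77 log units; beyond the scatter) and a 9.4-fold higher number from compound 1 to compound 3 (0.97 log units; beyond the scatter). Compound 4 `C[Si](C)(C)c1cn(C[C@H](O)[C@H]2OC(=O)C(OCc3ccccc3)=C2OCc2ccccc2)nn1` differs from compound 1 by a group of 4 heavy atoms (3 carbon, 1 silicon; no ring) in place of a group of 7 heavy atoms (6 carbon, 1 bromine; one six-membered aromatic ring of carbon only), on an aromatic carbon. For the measured compounds named here, the step that bears most directly on this is the one to compound 3, where tert-butyl also replaced 4-bromophenyl at the same place and the number rose modestly but beyond the scatter; the step to compound 2 points the same way. A rise of similar size is therefore expected, so compound 4 is expected to show a 6.9-fold higher number from compound 1 to compound 4 (0.84 log units; beyond the scatter). The estimate for compound 4 is 40000 nM, with a range from 15000 nM to 100000 nM.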

Compound 4, half-maximal inhibitory concentration: 52600 nM
For compound 4 the middle estimate is 1.3-fold (0.12 log units) below the measured one; low and high end bracket the measured number.
By their numbers in this assay, from the lowest: compound 1; then compounds 2, 4 and 3 (each within the scatter of the next).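

In this assay, silicon in place of the central carbon of tert-butyl makes no real difference, with a 1.0-fold lower number from compound 3 to compound 4 (0.02 log units; within the scatter), and the step from the 4-bromophenyl group is of the same size, with a 9.0-fold higher number from compound 1 to compound 4 (0.96 log units; beyond the scatter). The much larger sulfonyl-containing group also stays within the scatter of the silicon group, with a 1.5-fold higher number from compound 2 to compound 4 (0.18 log units; within the scatter). No measured evidence is available to explain these numbers. From the compounds shown here alone, it remains open whether the lower number of compound 1 goes with the aromatic ring or with its bromine. A plain phenyl group at the same place would separate the two.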